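Aryl phosphate thymidine series: stability step to compound 4

A few compounds are considered here, and "the series" means these few. Any claim that something is new, unique, unknown or untested is made for them only; others in the source may bear on it.

Measured so far:
compound 1 `Cc1cn([C@H]2C[C@H](N=[N+]=[N-])[C@@H](COP(=O)(O)Oc3ccc(Cl)cc3Cl)O2)c(=O)[nH]c1=O` — 3.03 h
compound 2 `Cc1cn([C@H]2C[C@H](N=[N+]=[N-])[C@@H](COP(=O)(O)Oc3ccncc3)O2)c(=O)[nH]c1=O` — 8.07 h
compound 3 `Cc1cn([C@H]2C[C@H](N=[N+]=[N-])[C@@H](COP(=O)(O)Oc3ccc(C#N)cc3)O2)c(=O)[nH]c1=O` — 7.08 h

In a physicochemical assay for metabolic stability, read by HPLC (a lower number here means that the compound disappears faster, a higher number that the compound lasts longer), compound 3 gives 7.08 h, the second highest of the three numbers. The gap to compound 2 is within the scatter: a 1.1-fold lower number from compound 2 to compound 3 (0.06 log units; within the scatter). The gap to compound 1 is beyond it: a 2.3-fold higher number from compound 1 to compound 3 (0.37 log units; beyond the scatter).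

Compound 4 `Cc1cn([C@H]2C[C@H](N=[N+]=[N-])[C@@H](COP(=O)(O)Oc3cncc(Cl)c3)O2)c(=O)[nH]c1=O` is the next member, with the change (5-chloropyridin-3-yl in place of 4-cyanophenyl on an oxygen).

For the measured compounds named here, the steps that bear on this change are a 2.3-fold higher number from compound 1 to compound 3 (0.37 log units; beyond the scatter) and a 2.7-fold higher number from compound 1 to compound 2 (0.43 log units; beyond the scatter). Both ring replacements that removed the 2,4-dichlorophenyl raised the number by a modest amount, and the pyridin-4-yl and 4-cyanophenyl rings themselves lie within the scatter of each other. The entering ring carries one chlorine and one ring nitrogen, so for compound 4 a step of a 1.3-fold lower number from compound 3 to compound 4 (0.11 log units; within the scatter) is expected, within the scatter. Compound 4 is estimated at 5.5 h, with a range from 3 h to 10 h.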

Compound 4, half-life: 7.27 h
Beside the measured number, compound 4's estimate is 1.3-fold (0.12 log units) below it, within the range that was stated.
By their numbers in this assay, from the lowest: compound 1; then compounds 3, 4 and 2 (each within the scatter of the next).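

In this assay, the 5-chloropyridin-3-yl ring on an oxygen sits with the rings of compound 2 and compound 3 (a 1.0-fold higher number from compound 3 to compound 4 (0.01 log units; within the scatter); a 1.1-fold lower number from compound 2 to compound 4 (0.05 log units; within the scatter)), even though the nitrile of compound 3 is gone and a chlorine and a ring nitrogen have entered. Against the 2,4-dichlorophenyl ring the step is clear (a 2.4-fold higher number from compound 1 to compound 4 (0.38 log units; beyond the scatter)), so a ring chlorine does not by itself place a compound with compound 1. No measured evidence explains these steps.

Still open, as far as these compounds go, is whether the number holds with an amine or a carboxylic acid on the ring. From the compounds shown here alone, a plain alkyl chain in place of the ring on this oxygen is equally open.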